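Dropping the methoxy of compound 1: an expectation

The source may hold more compounds than are shown below. What is called first, only, known or untested is meant among the compounds shown, and "the series" means these compounds.

Measured so far:
Compound 1 `COc1ccc(-c2nc3sc(Cc4ccccc4)nn3c2SC#N)cc1`: 3900 nM
Compound 2 `O=Cc1c(-c2ccc(F)cc2)nc2sc(CCC3CCCCC3)nn12`: 7100 nM

In a functional assay on cells (Cancer cell lines, Homo sapiens) for inhibition (on this read-out lower numbers stand for stronger inhibition of growth and higher numbers for weaker inhibition of growth), compound 1 gives 3900 nM and compound 2 gives 7100 nM; the two numbers lie within the scatter of each other, so no order between them can be drawn. Compound 3 `N#CSc1c(-c2ccccc2)nc2sc(Cc3ccccc3)nn12` differs from compound 1 by hydrogen in place of methoxy on an aromatic carbon. Within the data shown here, no step between measured compounds bears on this change, so the step in this assay is expected to stay within the scatter, perhaps leaning toward weaker inhibition. Compound 3 is expected to give 5500 nM, in a range from 2000 nM to 15000 nM. The step of a 1.4-fold higher number from compound 1 to compound 3 (0.15 log units; within the scatter) is expected to be small.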

Compound 3, concentration for 50% growth inhibition: 4400 nM
Beside the measured number, compound 3's estimate is 1.3-fold (0.10 log units) above it; low and high end bracket the measured number.
By their numbers in this assay, from the lowest: compounds 1, 3 and 2 (each within the scatter of the next).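

Replacing 4-methoxyphenyl with phenyl gives a 1.1-fold higher number from compound 1 to compound 3 (0.05 log units; within the scatter) in this assay. Among these compounds, this is the first single-place comparison, and it shows that, on this aromatic carbon para to a large group, the methoxy and hydrogen compounds cannot be told apart on this read-out. No supporting data bear on the reason for this result.

As far as these compounds go, whether an amine or a carboxylic acid at this place would separate from hydrogen remains open. The compounds shown also leave open how the other groups on the shared core contribute.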